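The source may hold more compounds than are shown below. What is called first, only, known or untested is meant among the compounds shown, and "the series" means these compounds.

Working notes on the series. Compound 1 `O=C(Nc1ccc(Oc2ccnc3[nH]ccc23)c(F)c1)c1cc(-c2ccccc2)ccn1` carries a plain phenyl on the shared core. In a functional assay on PC-3 cells (Homo sapiens) for cytotoxicity, read by MTT assay, with a stated time of 72 h (a higher number here means a weaker inhibitor, a lower number a stronger inhibitor), compound 1 gives > 10000 nM, which is a limit of the assay and not a number. Compound 2 `Cc1ccc(-c2ccnc(C(=O)Nc3ccc(Oc4ccnc5[nH]ccc45)c(F)c3)c2)cc1` gives 3970 nM in this assay, and compound 3 `Cc1ccc(-c2ccnc(C(=O)Nc3ccc(Oc4ccnc5[nH]ccc45)c(F)c3)c2)c(C)c1` gives 4010 nM. Compound 3 therefore holds the higher of the two numbers shown, with compound 2 as its nearest neighbour, and the third value shown is the limit of compound 1 (the limit of > 10000 nM in this assay, at which 1 of the 3 values shown sits).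

The measured steps are an at least 2.5-fold lower number from compound 1 to compound 2 (0.40 log units; beyond the scatter) and an at least 2.4-fold lower number from compound 1 to compound 3 (0.39 log units; beyond the scatter), both beyond the scatter, while the added methyl brings only a 1.0-fold higher number from compound 2 to compound 3 (0.00 log units; within the scatter), within the scatter.

Compound 4 `COc1ccc(-c2ccnc(C(=O)Nc3ccc(Oc4ccnc5[nH]ccc45)c(F)c3)c2)cc1` has not yet been measured. It differs from compound 3 by 4-methoxyphenyl in place of 2,4-dimethylphenyl on an aromatic carbon. The step from compound 2 to compound 3 shows that the extra methyl of the 2,4-dimethylphenyl contributes nothing beyond the scatter, so its removal is expected to cost nothing; whether methoxy in place of methyl on the 4-methoxyphenyl shifts the number is not tested by any step here. The step this implies, a 1.0-fold lower number from compound 3 to compound 4 (0.00 log units; within the scatter), is expected to stay within the scatter. Compound 4 is therefore estimated at 4000 nM, with a range of 1500 nM to 12000 nM.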

Compound 4, half-maximal inhibitory concentration: 20 nM
For compound 4 the middle estimate is 200-fold (2.30 log units) above the measured one; the measured number lies below the stated range.
By their numbers in this assay, from the lowest: compound 4; then compounds 2 and 3 (each within the scatter of the next). At a limit, above all of these: compound 1.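

In this assay, the group on this aromatic carbon, opposite the ring nitrogen, proves far more sensitive to its substituent than compounds 2 and 3 indicated: methoxy in place of methyl gives a 200-fold lower number from compound 2 to compound 4 (2.30 log units; beyond the scatter), although the extra methyl of compound 3 had left the number within the scatter of compound 2. The exchange of 2,4-dimethylphenyl for 4-methoxyphenyl gives a step of the same size, a 200-fold lower number from compound 3 to compound 4 (2.30 log units; beyond the scatter), so the gain follows the methoxy group in both comparisons and is not reached by either methyl-bearing ring. Against the plain phenyl the change gives an at least 500-fold lower number from compound 1 to compound 4 (2.69 log units; beyond the scatter), which is a bound and not an exact size, as it rests on a limit of the assay: the limit of > 10000 nM in this assay, at which 1 of the 4 values shown sits.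

On these data alone, whether the large step belongs to the oxygen alone or to the whole methoxy group stays open, and a hydroxy, ethoxy or dimethylamino group on the same phenyl would separate these readings. The compounds shown also leave open what lies behind the step, as no property of these compounds is given as measured.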